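The source may hold more compounds than are shown below. What is called first, only, known or untested is meant among the compounds shown, and "the series" means these compounds.

The measured compounds:

Compound 1, `CS(=O)(=O)N1CCC2(CC1)OOC1(CCCC1)OO2`. In a functional assay on Huh-7 cells (Homo sapiens) for cytotoxicity, read by MTT assay, with a stated time of 72 h (on this read-out higher numbers stand for lower toxicity in this test and lower numbers for higher toxicity in this test), compound 1 gives > 100 ug/mL, which is a limit of the assay and not a number.

Compound 2, `CCS(=O)(=O)N1CCC2(CC1)OOC1(CCCC1)OO2`. In this assay compound 2 gives > 100 ug/mL, again a limit rather than a number.

Compound 3, `CCCS(=O)(=O)N1CCC2(CC1)OOC1(CCCCC1)OO2`. In this assay compound 3 gives > 100 ug/mL, also a limit and not a number.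

Compound 2 differs from compound 1 by one change: methyl in place of hydrogen on a saturated chain carbon bound to a sulfonyl sulfur. The resulting step, a step that the two limits leave unreadable from compound 1 to compound 2, cannot be sized because of the limit of > 100 ug/mL in this assay, at which 3 of the 3 values shown sit. Compound 3 carries a different core from compound 1; the difference between the two cores is not broken down here.

Compound 4, `CCCCS(=O)(=O)N1CCC2(CC1)OOC1(CCCCC1)OO2`, is not yet measured. It differs from compound 3 by methyl in place of hydrogen on a saturated chain carbon, three bonds along the chain from a sulfonyl sulfur. This is the same kind of change as that from compound 1 to compound 2, but not the same: there the methyl entered on a saturated chain carbon bound to a sulfonyl sulfur, here it enters on a saturated chain carbon, three bonds along the chain from a sulfonyl sulfur.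

Since compound 3 stands only at a limit, and the earlier step of the same kind was left unreadable by two limits, the step from compound 3 to compound 4 in this assay is expected to be small, about a step that the limit leaves unreadable from compound 3 to compound 4. Compound 4 is therefore expected to show 150 ug/mL, with a range from 80 ug/mL to 400 ug/mL, most likely reported again as a limit.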

Compound 4, half-maximal cytotoxic concentration: > 100 ug/mL
Compound 4 was reported as a limit (the forecaster's own chance of this, stated with the estimate: 85%); the middle value is on the limit's open side.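

No step can be read from compound 3 to compound 4 in this assay, because both compounds sit at the same limit, which is a limit of the assay and not a number: the limit of > 100 ug/mL in this assay, at which 4 of the 4 values shown sit.

The compounds shown leave open where the true value of each one lies, and so whether going from propyl to butyl changes the read-out at all.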